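The compounds below may be only part of what the source reports. "The series", "measured", "known", "first", "only" and "open" are said of these compounds alone.

Of the compounds shown here, three built on one shared core have been measured in a functional assay on CHO cells for agonist activity at Alpha-2C adrenergic receptor (Homo sapiens); on this read-out lower numbers stand for smaller maximal responses and higher numbers for larger maximal responses. Compound 1 `CSc1ccc(C)cc1NCC1=NCCN1` gives 81% in this assay. Compound 2 `Cc1ccc(S(C)(=O)=O)c(NCC2=NCCN2)c1` gives 76% in this assay. Compound 3 `CS(=O)(=O)c1cc(F)ccc1NCC1=NCCN1` gives 32% in this assay, the lowest of the three numbers; its gaps to compound 2 and to compound 1 lie beyond the scatter, while the numbers of compound 1 and compound 2 lie within the scatter of each other, so no order can be read between those two.

Compound 2 and compound 1 differ in one place only: methylsulfanyl in place of methylsulfonyl on an aromatic carbon. That change made a step of a number 5 percentage points higher from compound 2 to compound 1 (within the scatter).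

Compound 4 `CSc1cc(F)ccc1NCC1=NCCN1` has not yet been measured in this assay. It differs from compound 3 by methylsulfanyl in place of methylsulfonyl on an aromatic carbon. Within the data shown here, this is the same kind of change as the one from compound 2 to compound 1, but not the same change: in compound 2 the place is para to a methyl group, whereas in compound 3 it is meta to a fluoro group. The difference between the core of compound 2 and the core of compound 3 is not broken down here.

Because the step of a number 5 percentage points higher from compound 2 to compound 1 (within the scatter) stayed within the scatter, a similarly small step is expected here, a number 6 percentage points higher from compound 3 to compound 4 (within the scatter), resting on that single earlier example. Compound 4 is therefore estimated to give 38% in this assay, with a likely range from 20% to 60%.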

Compound 4, largest response reached (reported as maximum), in percent of the reference or control that the assay uses: 82%
The estimate for compound 4 lay 44 percentage points below the measured number; measured number outside the range, above it.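

In this assay, putting methylsulfanyl in place of methylsulfonyl on an aromatic carbon made a large step on the core of compound 3: a number 50 percentage points higher from compound 3 to compound 4 (beyond the scatter). The same exchange therefore did not carry over with the same size from one core to the other: the same change on two cores in this assay, a number 5 percentage points higher (within the scatter) from compound 2 to compound 1 and a number 50 percentage points higher (beyond the scatter) from compound 3 to compound 4, 45 percentage points apart, beyond the scatter of two such steps What this shows is that, for these two pairs, a small step on one core gave no safe guide to the step on the other, though the change did not lower the number on either core; it does not show which difference between the two cores accounts for the gap, and two pairs are too few to support a general rule for the series.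

The compounds shown leave open how the same exchange would behave on a core carrying another group in place of the methyl or the fluoro, such as a chloro or a methoxy group, which could help show what the size of the step follows. They also leave open what would happen with a different group in the place of methylsulfanyl, such as an amine, a carboxylic acid or a longer alkyl chain.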